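The compounds below may be only part of what the source reports. "The series", "measured", "known", "first", "only" and "open" are said of these compounds alone.

Two compounds of the series carry numbers in an in vivo ADME assay on the whole organism for pharmacokinetics, with Rattus norvegicus as the target, at a dose of 10 mg/kg by the intravenous route; a higher number here means faster removal of the compound, a lower number slower removal. Compound 1 `C[C@@](CCc1ccc(-c2ccc(C#N)cc2)cc1)(C(=O)NO)S(C)(=O)=O` gives 53 mL/min/kg. Compound 2 `C[C@@](CCc1ccc(-c2ccc(O)cc2)cc1)(C(=O)NO)S(C)(=O)=O` gives 65 mL/min/kg. Among the compounds with values here, the one measured step, a 1.2-fold higher number from compound 1 to compound 2 (0.09 log units; within the scatter), is hydroxy in place of cyano on an aromatic carbon. Compound 2 thus holds the higher of the two numbers, but since that step lies within the scatter no order between compound 1 and compound 2 is claimed.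

Compound 3 `C[C@@](CCc1ccc(-c2ccc(O)cc2)cc1)(C(=O)O)S(C)(=O)=O` is not yet measured. It differs from compound 2 in one place: hydroxy in place of hydroxyamino on a carbonyl carbon The change sits on a carbonyl carbon whose other neighbours are a saturated chain carbon; cut one bond further out it reads hydroxycarbamoyl to carboxy. Within the data shown here, no measured step touches this part of the molecule; the only step known, a 1.2-fold higher number from compound 1 to compound 2 (0.09 log units; within the scatter), concerns an aromatic carbon elsewhere and was within the scatter, so it offers no guide to the size or direction of the present change. With only the value of compound 2 to rest on, no step beyond the scatter is assumed in this assay. Compound 3 is expected to give 50 mL/min/kg, within a range of 20 mL/min/kg to 120 mL/min/kg, an estimated step of a 1.3-fold lower number from compound 2 to compound 3 (0.11 log units; within the scatter).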

Compound 3, clearance: 15 mL/min/kg
The estimate for compound 3 lay 3.3-fold (0.52 log units) above the measured number; the whole stated range lies above it.
By their numbers in this assay, from the lowest: compound 3; then compounds 1 and 2 (each within the scatter of the next).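

In this assay, the carbonyl carbon proves to be a place where a single change moves the number: hydroxy in place of hydroxyamino gives a 4.3-fold lower number from compound 2 to compound 3 (0.64 log units; beyond the scatter) and is the only step shown that lies beyond the scatter. The step on the aromatic carbon, a 1.2-fold higher number from compound 1 to compound 2 (0.09 log units; within the scatter), stayed within the scatter, so among the compounds shown, only the change at the carbonyl carbon separates two compounds in this read-out. Nothing measured on this series explains the step from hydroxycarbamoyl to carboxy, and its size rests on this single pair of compounds.

Going by these compounds, it remains open whether a primary carboxamide or a methyl ester on the same carbonyl carbon would give a number closer to that of compound 2 or to that of compound 3, and so whether the step follows from losing the hydroxycarbamoyl group or from gaining the carboxy group. On these data alone, it is equally open whether the hydroxycarbamoyl to carboxy change gives a step of similar size in the presence of the nitrile of compound 1, where the aromatic hydroxy group is absent.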